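A few compounds are considered here, and "the series" means these few. Any claim that something is new, unique, unknown or untested is made for them only; others in the source may bear on it.

Measured compounds:
- compound 1 `COc1cc(NC(C)CCCNC(=O)Nc2cccc(Cl)c2)c2ncccc2c1`: 26000 nM
- compound 2 `COc1cc(NC(C)CCCNC(=O)Nc2ccc(C(F)(F)F)cc2)c2ncccc2c1`: 22000 nM
- compound 3 `COc1cc(NC(C)CCCNC(=O)NNC(=O)Nc2cccc(C(F)(F)F)c2)c2ncccc2c1`: 21000 nM

In a functional assay on SW-620 cells (Homo sapiens) for inhibition, read by MTT assay, with a stated time of 72 h (on this read-out lower numbers stand for stronger inhibition and higher numbers for weaker inhibition), compound 1 gives the highest of the three numbers, with compound 2 and compound 3 both within the scatter of it. Compound 4 `COc1cc(NC(C)CCCNC(=O)NNC(=O)Nc2ccc(O)cc2)c2ncccc2c1` is the untested member. It differs from compound 1 as follows: ((4-hydroxyphenyl)carbamoyl)amino in place of 3-chlorophenyl on an amide-type nitrogen. For the measured compounds named here, the only measured step on the same nitrogen is a 1.2-fold lower number from compound 1 to compound 2 (0.07 log units; within the scatter), a swap of aryl groups that left the number essentially unchanged. Compound 3, which carries a carbamoylamino extension of the same kind as compound 4, and compound 1 show values within the scatter of each other. Going by the values given here, no measured step therefore points to movement beyond the scatter in this assay. Compound 4 is accordingly expected at 24000 nM (range 8000 nM to 70000 nM), an expected step of a 1.1-fold lower number from compound 1 to compound 4 (0.03 log units; within the scatter).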

Compound 4, half-maximal inhibitory concentration: > 100000 nM
Compound 4: only a limit was reported; the forecaster's own chance of this, stated with the estimate: 20%; middle value at least 4.1-fold (0.61 log units) away from the limit.
By their numbers in this assay, from the lowest: compounds 3, 2 and 1 (each within the scatter of the next). At a limit, above all of these: compound 4.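

In this assay compound 4 gives > 100000 nM, a limit of the assay and not a number. For the compounds shown here, with the carbamoylamino extension kept, 4-hydroxyphenyl in place of 3-(trifluoromethyl)phenyl gives an at least 4.7-fold higher number from compound 3 to compound 4 (0.67 log units; beyond the scatter), so the terminal aryl group can move this read-out, which no earlier step showed. The larger replacement gives an at least 3.8-fold higher number from compound 1 to compound 4 (0.58 log units; beyond the scatter) and an at least 4.5-fold higher number from compound 2 to compound 4 (0.65 log units; beyond the scatter).

As far as these compounds go, whether the hydroxy group itself carries these steps remains open. A 4-methoxyphenyl or 4-aminophenyl group on the same extension would bear on that.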